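From 4-pentylphenyl to cyclopropyl: compound 1 and compound 4

This account rests on a few compounds, and the source may have more. Where it says the series, first, only, none or still open, it means among the compounds named here.

In an ADME assay on HFF cells (Homo sapiens) for cytotoxicity, read by MTT assay, with a stated time of 72 h (a higher number here means a weaker inhibitor, a lower number a stronger inhibitor), compound 1 `CCCCCc1ccc(-c2cn(C[C@H](O)[C@H]3OC(=O)C(OCc4ccccc4)=C3OCc3ccccc3)nn2)cc1` gives > 100000 nM, which is a limit of the assay and not a number. Compound 1 therefore stands at the limit of > 100000 nM in this assay, at which 2 of the 3 values shown sit. Compound 3 `COc1ccc(-c2cn(C/C=C3\OC(=O)C(OCc4ccccc4)=C3OCc3ccccc3)nn2)cc1` gives > 100000 nM, and this too is a limit. Compound 2 `CC(C)(C)OC(=O)N1CCN(C(=S)SCc2cn(C[C@H](O)[C@H]3OC(=O)C(OCc4ccccc4)=C3OCc3ccccc3)nn2)CC1` differs, with a measured value of 60 nM, so low values do occur in this small set.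

Compound 4 `O=C1O[C@H]([C@@H](O)Cn2cc(C3CC3)nn2)C(OCc2ccccc2)=C1OCc1ccccc1` carries cyclopropyl in place of 4-pentylphenyl on an aromatic carbon. For the measured compounds named here, no measured pair shows what such a change does in this assay, so no step beyond the scatter is expected. The estimated step is an at least 1.2-fold lower number from compound 1 to compound 4 (0.09 log units; that floor lies within the scatter). For compound 4, the expected value is 80000 nM, with an estimated range from 8000 nM to 150000 nM.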

Compound 4, half-maximal inhibitory concentration: 24300 nM
The estimate for compound 4 lay 3.3-fold (0.52 log units) above the measured number, and the stated range covers the measured number.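

In this assay, for the compounds shown here, this is the first step measured at this position, the aromatic carbon that carries the group: an at least 4.1-fold lower number from compound 1 to compound 4 (0.61 log units; beyond the scatter). It shows that replacing 4-pentylphenyl with cyclopropyl can move the number beyond the scatter. The true size of the step remains unknown, since compound 1 stands at a limit: the limit of > 100000 nM in this assay, at which 2 of the 4 values shown sit.

On these data alone, this single change removes both the pentyl chain and the six-membered aromatic ring, so their separate contributions remain open. A plain phenyl group at this position would separate them, and an aminomethyl group would test a different kind of substituent.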